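The source may hold more compounds than are shown below. What is called first, only, known or untested is meant among the compounds shown, and "the series" means these compounds.

Compound 1, `CCCn1ccnc1-c1cc(OC)c(OC)c(OC)c1`, in a functional assay on MDA-MB-231 cells (Homo sapiens) for antiproliferative activity, read by MTT assay, with a stated time of 72 h; a higher number here means a weaker inhibitor, a lower number a stronger inhibitor: > 100000 nM, a limit of the assay and not a number.
Compound 2, `COc1cc(-c2nccn2S(=O)(=O)c2ccccc2)cc(OC)c1OC`, in this assay: > 100000 nM, likewise only a limit.

Within the data shown here, compound 1 therefore stands at the ceiling of what the assay can report, and it shares that place with the only other measured compound, as the limit of > 100000 nM in this assay, at which 2 of the 2 values shown sit, shows. Compound 3, `COc1cc(-c2nccn2-c2ccc(Br)cc2)cc(OC)c1OC`, carries 4-bromophenyl in place of propyl on an aromatic nitrogen. Among the measured compounds shown here, no measured pair spans this change, so its effect is open; the step from compound 1 to compound 3 is expected to move toward stronger inhibition, though it may still stay at the limit. Compound 3 is estimated at 8000 nM, within 800 nM to 100000 nM, which as a step means an at least 12-fold lower number from compound 1 to compound 3 (1.09 log units; beyond the scatter).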

Compound 3, half-maximal inhibitory concentration: 8400 nM
Compound 3: the middle estimate sits 1.1-fold (0.02 log units) below what was measured, within the range that was stated.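

Among these compounds, compound 3 is the first compound here to give a real number in this assay, so this position on the aromatic nitrogen can respond to the group it carries. Putting 4-bromophenyl in place of propyl gives an at least 11-fold lower number from compound 1 to compound 3 (1.07 log units; beyond the scatter). The other two compounds stay at the ceiling: the limit of > 100000 nM in this assay, at which 2 of the 3 values shown sit.

As far as these compounds go, whether the ring or the bromine matters more remains open. A plain phenyl group or a 4-chlorophenyl group on this nitrogen would help separate the two.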